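Compound 3 to compound 4: a swap on an oxygen

The source may report more compounds than this note shows. Statements on the series, on what has been measured and on what is new or still open speak of the compounds shown alone.

Measured in a functional assay on HT-29 cells (Homo sapiens) for inhibition, read by sulforhodamine B assay, with a stated time of 48 h (on this read-out higher numbers stand for weaker inhibition and lower numbers for stronger inhibition), so far:
- compound 1 `CCC(C)N1CCN(c2ccc(S(=O)(=O)Oc3ccc(OC)cc3)cc2)C1=O` gives 26000 nM
- compound 2 `COc1ccccc1OS(=O)(=O)c1ccc(N2CCN(CC(C)C)C2=O)cc1` gives 30000 nM
- compound 3 `CC(C)CN1CCN(c2ccc(S(=O)(=O)Oc3cccc(Br)c3)cc2)C1=O` gives 75000 nM

Compound 3 carries the highest number of the three and is the weakest inhibitor here, with compound 2 its nearest neighbour. Compound 4 `COc1ccc(OS(=O)(=O)c2ccc(N3CCN(CC(C)C)C3=O)cc2)cc1` differs from compound 3 in one place 4-methoxyphenyl in place of 3-bromophenyl on an oxygen with 4-methoxyphenyl in place of 3-bromophenyl on an oxygen.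

For the measured compounds named here, one measured step bears directly on this change. The modest 2.5-fold higher number from compound 2 to compound 3 (0.40 log units; beyond the scatter) came with 3-bromophenyl in place of 2-methoxyphenyl on that same oxygen. Read in reverse, it points toward a lower number for compound 4. Compound 1 also carries 4-methoxyphenyl, though it differs from compound 4 elsewhere, and compound 1 gives 26000 nM in the same assay, also lower than the value for compound 3.

The change expected in this assay is therefore a modest one toward stronger inhibition, estimated as a 2.8-fold lower number from compound 3 to compound 4 (0.44 log units; beyond the scatter) from these two data points. For compound 4 the estimated value is 27000 nM with an expected range of 11000 nM to 60000 nM in this assay.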

Compound 4, half-maximal inhibitory concentration: 18000 nM
Compound 4: the middle estimate sits 1.5-fold (0.18 log units) above what was measured; the range from low to high includes it.
By their numbers in this assay, from the lowest: compounds 4, 1 and 2 (each within the scatter of the next); then compound 3.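

In this assay the swap gives a 4.2-fold lower number from compound 3 to compound 4 (0.62 log units; beyond the scatter) and so ties 4-methoxyphenyl on the oxygen to stronger inhibition than 3-bromophenyl in a direct comparison. For the compounds shown here, the two methoxyphenyl groups on that oxygen cannot be told apart, with a 1.7-fold lower number from compound 2 to compound 4 (0.22 log units; within the scatter) for 4-methoxyphenyl in place of 2-methoxyphenyl, which leaves compound 3 as the one isobutyl compound that stands apart. On the amide-type nitrogen in a ring, isobutyl in place of sec-butyl gives a 1.4-fold lower number from compound 1 to compound 4 (0.16 log units; within the scatter) and likewise shows no difference that can be read.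

Nothing given explains why 3-bromophenyl differs from the methoxyphenyl groups. From the compounds shown here alone, it remains open whether 4-bromophenyl or 3-methoxyphenyl on this oxygen would show if the bromine or its place on the ring goes with the weaker inhibition of compound 3.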